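The source may hold more compounds than are shown below. What is called first, only, known or untested is meant among the compounds shown, and "the series" means these compounds.

Measured so far:
compound 1 `COc1cc(-c2cc(/C=C/C(=O)c3ccc(Cl)c(Cl)c3)[nH]n2)cc(OC)c1OC` — 4190 nM
compound 2 `COc1ccc(-c2cc(/C=C/C(=O)c3cc(OC)c(OC)c(OC)c3)[nH]n2)cc1OC` — 5470 nM
compound 3 `COc1cc(C(=O)/C=C/c2cc(-c3cc(OC)c(OC)c(OC)c3)n[nH]2)cc(OC)c1OC` — 3200 nM

The three compounds were tested in a functional assay on SK-OV-3 cells (Homo sapiens) for inhibition, read by sulforhodamine B assay, with a stated time of 48 h; on this read-out higher numbers stand for weaker inhibition of growth and lower numbers for stronger inhibition of growth. Compound 1 gives a number that sits between those of compound 2 and compound 3, and both gaps lie within the usual scatter of this assay, so the three are not distinguishable on these data. Among the measured compounds shown here, the one step that can be read directly, a 1.7-fold lower number from compound 2 to compound 3 (0.23 log units; within the scatter), also stays within the scatter.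

Compound 4 `COc1cc(-c2cc(/C=C/C(=O)c3ccc(F)c(F)c3)[nH]n2)cc(OC)c1OC` differs from compound 1 by 3,4-difluorophenyl in place of 3,4-dichlorophenyl on a carbonyl carbon. For the measured compounds named here, no measured pair shows this exchange of one halogenated phenyl for another, and the only measured step concerns a different part of the core, so nothing here points to a shift in either direction beyond the scatter. Compound 4 is therefore expected to give about 4500 nM, with a likely range from 1800 nM to 11000 nM. That corresponds to an expected step of a 1.1-fold higher number from compound 1 to compound 4 (0.03 log units; within the scatter), which is not expected to exceed the scatter.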

Compound 4, concentration for 50% growth inhibition: 3530 nM
Compound 4: the middle estimate sits 1.3-fold (0.11 log units) above what was measured, and the stated range covers the measured number.
By their numbers in this assay, from the lowest: compounds 3, 4, 1 and 2 (each within the scatter of the next).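

Exchanging 3,4-dichlorophenyl for 3,4-difluorophenyl on the carbonyl carbon gives, in this assay, a 1.2-fold lower number from compound 1 to compound 4 (0.07 log units; within the scatter), so the two compounds cannot be told apart. Among the compounds shown here, this is the first readable step at this place, since the only earlier one, methoxy in place of hydrogen on an aromatic carbon, concerned a different part of the core, and it shows that one halogen pair can stand in for the other here with no difference beyond the scatter. Nothing available speaks to what lies behind this result.

Going by these compounds, whether a phenyl carrying an amine or a carboxylic acid on the same carbonyl carbon would move the number beyond the scatter remains open. So does the effect of a single chlorine or an unsubstituted phenyl there.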